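Nitrofuran-Thiazole Amides: Vero Cell Cytotoxicity and an Acetamido Analogue

The source may hold more compounds than are shown below. What is called first, only, known or untested is meant among the compounds shown, and "the series" means these compounds.

Measured compounds:
compound 1 `COc1cccc(-c2csc(NC(=O)c3ccc([N+](=O)[O-])o3)n2)c1` gives 58700 nM
compound 2 `O=C(Nc1nc(-c2cccc(C(F)(F)F)c2)cs1)c1ccc([N+](=O)[O-])o1` gives 23900 nM

The two compounds share a core and differ only in the group on the pendant aromatic ring. In an ADME assay on Vero cells (Chlorocebus sabaeus) for cytotoxicity, read by MTT assay, with a stated time of 72 h (a lower number here means a stronger inhibitor, a higher number a weaker inhibitor), compound 1 gives 58700 nM, while compound 2 gives 23900 nM; the step of a 2.5-fold lower number from compound 1 to compound 2 (0.39 log units; beyond the scatter) is beyond the scatter but modest. Within the data shown here, compound 2 therefore stands with the lowest number of the two, with compound 1 the only neighbour.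

Compound 3 `CC(=O)Nc1cccc(-c2csc(NC(=O)c3ccc([N+](=O)[O-])o3)n2)c1` has not yet been measured. The change from compound 2 to compound 3 is acetamido in place of trifluoromethyl on an aromatic carbon. Among the measured compounds shown here, only one measured step bears on it, the exchange of methoxy for trifluoromethyl, and it moved the number by a modest amount. For the measured compounds named here, replacing trifluoromethyl with a group carrying a hydrogen-bond donor and acceptor is a different change, so the single step gives only a rough guide. Compound 3 is expected to move away from compound 2, with the number rising modestly, by a 1.9-fold higher number from compound 2 to compound 3 (0.27 log units; within the scatter). The estimate for compound 3 in this assay is 45000 nM, within a range from 20000 nM to 100000 nM.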

Compound 3, half-maximal inhibitory concentration: 57600 nM
Estimate against measurement, compound 3: 1.3-fold (0.11 log units) below; low and high end bracket the measured number.
By their numbers in this assay, from the lowest: compound 2; then compounds 3 and 1 (each within the scatter of the next).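

In this assay, the exchange of trifluoromethyl for acetamido gives a 2.4-fold higher number from compound 2 to compound 3 (0.38 log units; beyond the scatter) and is modest, so this position on the six-membered aromatic ring responds to a second kind of replacement, here one that brings in a hydrogen-bond donor and a hydrogen-bond acceptor where trifluoromethyl has neither. The comparison with methoxy adds something the first pair could not show: a 1.0-fold lower number from compound 1 to compound 3 (0.01 log units; within the scatter) lies within the scatter, so acetamido and methoxy cannot be told apart in this assay, and among these three compounds only compound 2, with trifluoromethyl, stands apart, with the lowest number. The data do not show what sets compound 2 apart from the other two. No measurement of any property of these groups accompanies the values.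

Going by these compounds, it remains open whether an amine, a carboxylic acid or a chlorine atom at this place would fall with compound 1 and compound 3 or with compound 2, and whether the pattern would hold for any other group. On these data alone, the shared core is identical in all three compounds, so the effect of a change anywhere else in the structure also remains open.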